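The source may report more compounds than this note shows. Statements on the series, on what has been measured and on what is new or still open speak of the compounds shown alone.

In a functional assay on a cell-free system (Platelet, plasma, Homo sapiens) for inhibition (on this read-out higher numbers stand for weaker inhibition and lower numbers for stronger inhibition), compound 1 (`O=C(Nc1cccc(OCc2ccccc2)c1)C1CCNCC1`) gives 229000 nM and compound 2 (`O=C(Nc1cccc(OCc2ccc(-c3ccc(F)cc3)cc2)c1)C1CCNCC1`) gives 35000 nM on the same read-out. Compound 3 (`O=C(Nc1cccc(OCc2ccc(-c3c(F)cccc3F)cc2)c1)C1CCNCC1`) has only the entry "not determined" (no result reported) here, so it offers no number to start from. Compound 4 (`O=C(Nc1cccc(OCc2ccc(-c3ccc(C(F)(F)F)cc3)cc2)c1)C1CCNCC1`) carries 4-(trifluoromethyl)phenyl in place of 2,6-difluorophenyl on an aromatic carbon. Among the measured compounds shown here, the one measured step that bears on this is modest: a 6.5-fold lower number from compound 1 to compound 2 (0.82 log units; beyond the scatter) when 4-fluorophenyl replaces hydrogen on an aromatic carbon. For the measured compounds named here, with no number for compound 3, no size of step from it can be expected in this assay. Compound 4 keeps a substituted phenyl there, so it is expected to lie in the region of compound 2 at 35000 nM on this read-out. In this assay compound 4 is expected at 30000 nM with 10000 nM to 90000 nM as the estimated range.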

Compound 4, half-maximal inhibitory concentration: 65700 nM
Estimate against measurement, compound 4: 2.2-fold (0.34 log units) below, within the range that was stated.
By their numbers in this assay, from the lowest: compounds 2 and 4 (each within the scatter of the next); then compound 1.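

In this assay, trifluoromethyl in place of fluoro gives a 1.9-fold higher number from compound 2 to compound 4 (0.27 log units; within the scatter), so the two groups cannot be told apart at this position. Against hydrogen, the 4-(trifluoromethyl)phenyl group gives a 3.5-fold lower number from compound 1 to compound 4 (0.54 log units; beyond the scatter), so a second substituted phenyl also lowers the number, as 4-fluorophenyl did. Compound 3 has no number, so its step cannot be read, and nothing measured here accounts for these values. From the compounds shown here alone, what stays open is whether an amine or a carboxylic acid in place of trifluoromethyl would move the number beyond the scatter.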